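A few compounds are considered here, and "the series" means these few. Any claim that something is new, unique, unknown or untested is made for them only; others in the source may bear on it.

Three compounds sharing one core have been examined in a functional assay on the whole organism (Tail, strain ICR) with Mus musculus as the target, in the tail flick test, with a stated time of 150 min, at a dose of 25 umol/kg by the oral route; a higher number here means a stronger effect of the compound at the dose given, a lower number a weaker effect. Compound 1, `O=C(CN(c1nc(Cl)nc2[nH]cnc12)C1CC1)N[C@@H](CO)C(=O)OCc1ccccc1`, gives 27.9%. Compound 2, `C[C@H](NC(=O)CN(c1nc(Cl)nc2[nH]cnc12)C1CC1)C(=O)OCc1ccccc1`, gives 23%. Compound 3, `O=C(O)[C@@H]1CCCN1C(=O)CN(c1nc(Cl)nc2[nH]cnc12)C1CC1`, gives 7.29%. Going by the values given here, the only single-point step among them runs a number 4.9 percentage points lower from compound 1 to compound 2 (within the scatter), so the hydroxy on the saturated chain carbon made no difference that rises above the scatter. Compound 2 therefore stands second of the three numbers: its nearest neighbour, compound 1, lies within the scatter of it, while compound 3 lies beyond the scatter below it.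

The next compound, compound 4, `O=C(CN(c1nc(Cl)nc2[nH]cnc12)C1CC1)NCC(=O)OCc1ccccc1`, follows from compound 2 by hydrogen in place of methyl on a saturated chain carbon bound to an amide-type nitrogen and a carbonyl carbon. Among the compounds with values here, no measured step bears directly on this change. Within the data shown here, the one step that is known, from compound 1 to compound 2, touched a chain carbon of the same amino-acid residue and stayed within the scatter, and nothing in the data says that taking away the methyl should behave otherwise. The expectation for compound 4 in this assay is therefore a step of a number 3 percentage points lower from compound 2 to compound 4 (within the scatter), which stays within the scatter. On that basis the estimate for compound 4 is 20%, expected to fall between 8% and 33%.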

Compound 4, a percentage reported as activity, at one dose (the size of the read-out at that dose, not a potency): 18%
Beside the measured number, compound 4's estimate is 2 percentage points above it; low and high end bracket the measured number.
By their numbers in this assay, from the lowest: compound 3; then compounds 4, 2 and 1 (each within the scatter of the next).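

Hydrogen in place of methyl on a saturated chain carbon bound to an amide-type nitrogen and a carbonyl carbon gives a number 5 percentage points lower from compound 2 to compound 4 (within the scatter) in this assay, and hydrogen in place of hydroxymethyl at the same place gives a number 9.9 percentage points lower from compound 1 to compound 4 (within the scatter) on that same read-out. The earlier step compared only the methyl and hydroxymethyl forms at this carbon, whereas these two show that the form with no side group on this carbon also stays within the scatter of both, so that none of the three groups seen here separates from the others at this dose. The data offered here contain nothing that explains these steps or their small size.

Still open, on these data alone, is what a larger or differently built group at this carbon would do, such as a longer chain, an amine or a carboxylic acid, since hydrogen, methyl and hydroxymethyl cover only a narrow range of substituents. Going by these compounds alone, also open is what the benzyl ester itself contributes, as compound 3 differs from the other compounds in more than one place and no single-point step connects it to them.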